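This account rests on a few compounds, and the source may have more. Where it says the series, first, only, none or still open, it means among the compounds named here.

Measured so far:
compound 1, `O=C(Nc1ccc(-c2cscn2)cc1)C1CCCN(Cc2cccc(F)c2)C1`, gives 2450 nM in a functional assay on A-375 cells (Homo sapiens) for antiproliferative activity; on this read-out lower numbers stand for stronger inhibition and higher numbers for weaker inhibition;
compound 2, `O=C(Nc1ccc(-c2cscn2)cc1)C1CCCN(Cc2cc(F)cc(F)c2)C1`, gives 1360 nM in this assay.

Compound 2 holds the number at the low end of these two, yet the step of a 1.8-fold lower number from compound 1 to compound 2 (0.26 log units; within the scatter) is within the scatter, so compound 1 and compound 2 cannot be told apart on this read-out. Compound 3, `O=C(Nc1ccc(-c2cscn2)cc1)C1CCCN(Cc2ccc(Cl)c(Cl)c2)C1`, is not yet measured. It differs from compound 2 by 3,4-dichlorophenyl in place of 3,5-difluorophenyl on a saturated chain carbon bound to an amine nitrogen in a ring. Going by the values given here, the only measured step, a 1.8-fold lower number from compound 1 to compound 2 (0.26 log units; within the scatter), concerns a single added fluorine and stayed within the scatter; it bears on this change only loosely, since here both fluorines leave and two chlorines enter at other places on the same ring. With that thin basis, the step expected from compound 2 to compound 3 in this assay is a 1.0-fold lower number from compound 2 to compound 3 (0.02 log units; within the scatter), with no direction beyond the scatter. For compound 3 the estimate is 1300 nM, within a range from 450 nM to 3800 nM.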

Compound 3, half-maximal inhibitory concentration: 1730 nM
Estimate against measurement, compound 3: 1.3-fold (0.12 log units) below, within the range that was stated.
By their numbers in this assay, from the lowest: compounds 2, 3 and 1 (each within the scatter of the next).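

In this assay the exchange of both fluorines for two chlorines at other places on the ring appears as a 1.3-fold higher number from compound 2 to compound 3 (0.10 log units; within the scatter) and the exchange of the single fluorine for the same 3,4-dichlorophenyl group appears as a 1.4-fold lower number from compound 1 to compound 3 (0.15 log units; within the scatter) on the same saturated chain carbon bound to an amine nitrogen in a ring. Together with the earlier step, this means that compounds 1, 2 and 3 cannot be told apart on this read-out, even though the kind, number and placing of the halogens on this ring all differ among them. No supporting measurement bears on why these three sit so close together.

The compounds shown cover only halogens on this benzyl ring. Open, from the compounds shown here alone, is how the read-out responds to a methoxy group or an amine on that ring, or to a longer chain in place of the benzyl link.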